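A few compounds are considered here, and "the series" means these few. Any claim that something is new, unique, unknown or untested is made for them only; others in the source may bear on it.

Compound 1 `O=C(NC[C@@H]1[C@H]2CN(C(=O)C3CC3c3cc(Cl)cc(Cl)c3)C[C@@H]12)c1ccc2[nH]c(=O)oc2c1` gives 64 10^-6 cm/s in an ADME assay on Caco-2 cells (Homo sapiens) for permeability, in the apical to basolateral direction, with a stated time of 90 min, tested at 10 uM; a lower number here means that the compound crosses the layer more slowly, a higher number that the compound crosses the layer faster
Compound 2 `Cc1ccc(COC(=O)N2C[C@@H]3[C@@H](CNC(=O)c4ccc5[nH]c(=O)oc5c4)[C@@H]3C2)nc1` gives 1 10^-6 cm/s in this assay

Of these two numbers, compound 2 holds the lower (1 10^-6 cm/s). Compound 3 `Cc1cc(COC(=O)N2C[C@@H]3[C@@H](CNC(=O)c4ccc5[nH]c(=O)oc5c4)[C@@H]3C2)no1` differs from compound 2 by a single change: 5-methyl-1,2-oxazol-3-yl in place of 5-methylpyridin-2-yl on a saturated chain carbon bound to an oxygen next to a carbonyl group. Among the compounds with values here, the only measured step (a 64-fold lower number from compound 1 to compound 2 (1.81 log units; beyond the scatter)) is large and beyond the scatter. It exchanges a whole group on a carbonyl carbon, however, so it bears on this change only loosely. Within the data shown here, no measured step exchanges one of these two aromatic groups for the other, and the size of the change in this assay remains an expectation. The rest of compound 3 matches compound 2, so the expectation stays close to compound 2 (1 10^-6 cm/s). The expected step (a 1.5-fold higher number from compound 2 to compound 3 (0.18 log units; within the scatter)) is small, slightly upward and not beyond the scatter. In this assay the estimate for compound 3 is 1.5 10^-6 cm/s (expected range 0.5 10^-6 cm/s to 4 10^-6 cm/s).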

Compound 3, apparent permeability in the Caco-2 assay: 2 10^-6 cm/s
Compound 3: the middle estimate sits 1.3-fold (0.12 log units) below what was measured, within the range that was stated.
By their numbers in the Caco-2 assay, from the lowest: compounds 2 and 3 (each within the scatter of the next); then compound 1.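

In the Caco-2 assay compound 2 gives 1 10^-6 cm/s and compound 3 gives 2 10^-6 cm/s as its number. In the Caco-2 assay the step is a 2.0-fold higher number from compound 2 to compound 3 (0.30 log units; within the scatter) and so at this place, on a saturated chain carbon bound to an oxygen next to a carbonyl group, 5-methyl-1,2-oxazol-3-yl and 5-methylpyridin-2-yl cannot be told apart, despite the different ring size and acceptor count. The second comparison, a 32-fold lower number from compound 1 to compound 3 (1.51 log units; beyond the scatter), shows that the large gap first seen with compound 2 also holds with this five-membered aromatic ring, so both groups shown at this place stay far from compound 1. In a physicochemical assay for solubility, with a stated time of 24 h, at pH 2.2 (on this read-out lower numbers stand for lower solubility and higher numbers for higher solubility), compound 2 has > 92 ug/mL as its value, which is a limit. In the physicochemical assay compound 3 has > 86 ug/mL as its value, which is also a limit. The step between these two compounds cannot be read, and nothing measured here accounts for the permeability numbers.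

Still open, as far as these compounds go, is whether an amine or a carboxylic acid on the methyl carbon at this place, or a plain phenyl ring, would move the number in the Caco-2 assay away from compound 2 and compound 3. Also open, from the compounds shown here alone, is which part of the exchanged group on the carbonyl carbon carries the large steps from compound 1, since those steps replace the whole group at once.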